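The source may hold more compounds than are shown below. What is called first, only, known or untested is meant among the compounds shown, and "the series" means these compounds.

Compound 1, with the structure `COc1ccc2nc(NC3CCCCC3)c(S(C)(=O)=O)nc2c1`, and compound 2, with the structure `COc1ccc2nc(S(C)(=O)=O)c(NC3CCCCC3)nc2c1`, are built from the same atoms joined differently; the difference between the two cores is not broken down here. In an ADME assay on HepG2 cells (Homo sapiens) for cytotoxicity, read by CellTiter-Glo, with a stated time of 48 h (on this read-out lower numbers stand for higher toxicity in this test and higher numbers for lower toxicity in this test), compound 1 gives 12600 nM, the lowest of the three measured values, while compound 2 gives 79400 nM. Compound 3, with the structure `COc1ccc2nc(S(C)(=O)=O)c(NCC(C)C)nc2c1`, is obtained from compound 2 by the change (isobutyl in place of cyclohexyl on a nitrogen on an aromatic ring), and this change gave the step of no change at the digits printed from compound 2 to compound 3 (within the scatter). In this assay compound 3 gives 79400 nM. Compound 4, with the structure `COc1ccc2nc(NCC(C)C)c(S(C)(=O)=O)nc2c1`, has not been measured; it is obtained from compound 1 by the change (isobutyl in place of cyclohexyl on a nitrogen on an aromatic ring), the same change at the same kind of place, on the core of compound 1 rather than that of compound 2. Going by the values given here, since the one recorded instance of this change, from compound 2 to compound 3, left the value unchanged within the scatter, the step from compound 1 to compound 4 is expected to be no change at the digits printed from compound 1 to compound 4 (within the scatter). On that basis compound 4 is estimated to give 12600 nM, with a likely range from 5000 nM to 35000 nM.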

Compound 4, half-maximal cytotoxic concentration: 12600 nM
Compound 4: the middle estimate sits on the measured number at the digits printed; measured number inside the range.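

In this assay, the exchange of cyclohexyl for isobutyl on the nitrogen on the aromatic ring gave no change at the digits printed from compound 1 to compound 4 (within the scatter), and the two cores can be set side by side: the same change on two cores in this assay, no change at the digits printed (within the scatter) from compound 2 to compound 3 and no change at the digits printed (within the scatter) from compound 1 to compound 4, 1.0-fold (0.00 log units) apart, within the scatter of two such steps. This shows that, for this one pair of groups, the exchange carried from one core to the other with the same outcome, so the earlier step was a sound guide here. It does not show that the same holds for other exchanges, since both instances are steps without a change, and two such steps cannot show whether a change that moved the value would carry over in the same way.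

On these data alone, it remains open whether a longer chain, a benzyl group or a chain ending in an amine on that nitrogen would also give matching steps on the two cores. As far as these compounds go, what a carboxylic acid or an amide in place of the methoxy group would do on either core also stays open.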